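A few compounds are considered here, and "the series" means these few. Any claim that something is new, unique, unknown or untested is made for them only; others in the source may bear on it.

Measured so far:
- compound 1, `CC[C@H](C)[C@H](NC(=O)CN(c1ncnc2c1ncn2C1CCCCO1)C1CC1)C(=O)OCc1ccccc1`: 27.4%
- compound 2, `O=C(CN(c1ncnc2c1ncn2C1CCCCO1)C1CC1)N[C@@H](CO)C(=O)OCc1ccccc1`: 46.7%
- compound 3, `C[C@H](NC(=O)CN(c1ncnc2c1ncn2C1CCCCO1)C1CC1)C(=O)OCc1ccccc1`: 53%

In a functional assay on the whole organism (Tail, strain ICR) with Mus musculus as the target, in the tail flick test, with a stated time of 60 min, at a dose of 25 umol/kg by the oral route (a higher number here means a stronger effect of the compound at the dose given, a lower number a weaker effect), compound 3 gives the highest of the three numbers, yet its gap to compound 2 lies within the scatter, so the two cannot be ranked; only compound 1 sits clearly lower, as the step of a number 25.6 percentage points higher from compound 1 to compound 3 (beyond the scatter) shows.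

Compound 4, `CC(C)(C)OC(=O)NCCCC[C@H](NC(=O)CN(c1ncnc2c1ncn2C1CCCCO1)C1CC1)C(=O)OCc1ccccc1`, differs from compound 3 by 3-((tert-butoxycarbonyl)amino)propyl in place of hydrogen on a saturated chain carbon, two bonds along the chain from an amide-type nitrogen and a carbonyl carbon.

Among the measured compounds shown here, two measured steps touch the same place. Replacing the hydroxy of compound 2 by hydrogen gave a number 6.3 percentage points higher from compound 2 to compound 3 (within the scatter), a change of no weight. Replacing the sec-butyl of compound 1 by methyl gave a number 25.6 percentage points higher from compound 1 to compound 3 (beyond the scatter), a real gain, which read backwards means that a larger group at this carbon went with a lower number. For the measured compounds named here, the group entering in compound 4 is far larger than sec-butyl, so a drop in this assay is the expectation, of a size at least like that seen between compound 1 and compound 3, though no measured compound carries anything of this length, which leaves the range wide.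

Compound 4 is therefore expected to show a number 28 percentage points lower from compound 3 to compound 4 (beyond the scatter), landing at about 25%, with a range from 8% to 45%.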

Compound 4, a percentage reported as activity, at one dose (the size of the read-out at that dose, not a potency): 32.7%
Beside the measured number, compound 4's estimate is 7.7 percentage points below it; the measured number falls inside the stated range.
By their numbers in this assay, from the lowest: compounds 1 and 4 (each within the scatter of the next); then compounds 2 and 3 (each within the scatter of the next).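

In this assay, the change to the long group gives a number 20.3 percentage points lower from compound 3 to compound 4 (beyond the scatter) and, set against the hydroxymethyl group, a number 14 percentage points lower from compound 2 to compound 4 (beyond the scatter), so both steps are real losses. Set against sec-butyl, however, the same chain gives a number 5.3 percentage points higher from compound 1 to compound 4 (within the scatter), which means that compound 1 and compound 4 cannot be told apart despite the great difference in the length of their groups. The earlier link between a larger group at this carbon and a lower number therefore does not simply continue with size: compound 4 fits that link when compared with compound 2 and compound 3, but goes against any further loss beyond sec-butyl, and nothing available explains this.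

The compounds shown cannot separate the effect of chain length from that of the tert-butoxycarbonyl group at the end of the chain, since no compound carries a plain butyl chain or the same chain ending in a free amine. A carboxylic acid at this carbon, or a benzyl group in place of the sec-butyl, would show whether groups of other kinds also settle at this level or return to the level of compound 2 and compound 3.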